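This account rests on a few compounds, and the source may have more. Where it says the series, first, only, none or still open, it means among the compounds named here.

In an ADME assay for permeability, using PAMPA, at pH 6.5 (on this read-out higher numbers stand for higher permeability and lower numbers for lower permeability), compound 1 `Cc1ccccc1-n1nc(-c2c(-c3ccc(F)cc3)nn3c2NCCC3)ccc1=O` gives 30 10^-6 cm/s and compound 2 `Cc1ccccc1-n1nc(-c2c(-c3ccc(F)cc3)nn3c2N[C@@H](CO)CC3)ccc1=O` gives 23 10^-6 cm/s. These two numbers sit within the usual scatter of each other, so compound 2 cannot be separated from compound 1 on this evidence. Compound 3 `Cc1ccccc1-n1nc(-c2c(-c3ccc(F)cc3)nn3c2N[C@H](CO)CC3)ccc1=O` has not yet been measured. Its difference from compound 2 is purely one of spatial arrangement: the two compounds have the same atoms and bonds and differ only in configuration as drawn: 1 of 1 stereo elements differ; a stereocentre at a saturated ring carbon is drawn R in compound 2 and S in compound 3. For the measured compounds named here, no measured pair here isolates such a change. The nearest evidence is a 1.3-fold lower number from compound 1 to compound 2 (0.12 log units; within the scatter), which came with hydroxymethyl in place of hydrogen on a saturated ring carbon and stayed within the scatter. No change beyond the scatter is therefore expected in this assay. The expected result is a 1.0-fold higher number from compound 2 to compound 3 (0.02 log units; within the scatter), an estimated step that remains within the scatter. For compound 3 the estimated value is 24 10^-6 cm/s, with an expected range of 12 10^-6 cm/s to 45 10^-6 cm/s.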

Compound 3, apparent permeability: 22 10^-6 cm/s
For compound 3 the middle estimate is 1.1-fold (0.04 log units) above the measured one, and the stated range covers the measured number.
By their numbers in this assay, from the lowest: compounds 3, 2 and 1 (each within the scatter of the next).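

In this assay, reversing the drawn stereocentre at the saturated ring carbon gives a 1.0-fold lower number from compound 2 to compound 3 (0.02 log units; within the scatter), so this read-out does not tell the two configurations apart. Hydroxymethyl in place of hydrogen, now in the S form, gives a 1.4-fold lower number from compound 1 to compound 3 (0.13 log units; within the scatter); the earlier compounds showed this only for the R form, and now neither form can be separated from the compound that carries hydrogen there. The stereocentre can be read directly from this pair, because only one thing separates the two compounds: the fact that compounds 2 and 3 differ only in the configuration as drawn.

Still open, from the compounds shown here alone, is whether a different group on this ring carbon, such as an aminomethyl group, a carboxylic acid or a longer hydroxyalkyl chain, would move the number beyond the scatter. Going by these compounds, whether the two configurations also match on any other read-out remains open too.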